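The source may hold more compounds than are shown below. What is called first, only, known or untested is meant among the compounds shown, and "the series" means these compounds.

Compound 1, `Cc1[nH]c2ccccc2c1C1=CCC(NCc2ccc(OCC(=O)NO)cc2F)CC1`: 170 nM
Compound 2, `Cc1ccc2[nH]cc(C3=CCN(Cc4ccc(OCC(=O)NO)cc4)CC3)c2c1`: 3960 nM
Compound 3, `O=C(COc1ccc(C(=O)N2CC=C(c3c[nH]c4ccc(F)cc34)CC2)cc1)NO`: > 5000 nM

Three compounds carry a hydroxamic acid on a phenoxyacetyl arm and have been tested in a functional assay on SW480 cells (Homo sapiens) for antiproliferative activity, with a stated time of 72 h; on this read-out higher numbers stand for weaker inhibition and lower numbers for stronger inhibition. Compound 1 gives 170 nM, while compound 2 gives 3960 nM, a far weaker result. For compound 3 the assay reports no number at all, only a limit, > 5000 nM. On these data alone, compound 3 thus stands at the limit of > 5000 nM in this assay, at which 1 of the 3 values shown sits, the weakest position among the values shown, and its true potency is unknown beyond that limit.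

Compound 4, `O=C(COc1ccc(C(=O)N2CC=C(c3c[nH]c4cccc(F)c34)CC2)cc1)NO`, is built from the same atoms as compound 3 but joined differently: 4-fluoro-1H-indol-3-yl in place of 5-fluoro-1H-indol-3-yl on a double-bonded ring carbon. The amide link to the ring nitrogen, which compound 3 shares with compound 4 and which is absent from compound 1 and compound 2, is kept unchanged. Going by the values given here, no measured pair in this set isolates a move of the fluorine on the indole, so the size of the step cannot be read from the data. With compound 3 already at the limit, the step from compound 3 to compound 4 in this assay is expected to be none beyond the scatter, and compound 4 is most likely to return another limit. Compound 4 is therefore estimated at 7000 nM, with an expected range from 2500 nM to 20000 nM. The expected step that the limit leaves unreadable from compound 3 to compound 4 is small in either direction.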

Compound 4, half-maximal inhibitory concentration: 1490 nM
Compound 4: middle estimate off by 4.7-fold (0.67 log units), on the high side; measured number outside the range, below it.
By their numbers in this assay, from the lowest: compound 1; then compound 4; then compound 2. At a limit, above all of these: compound 3.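

In this assay, 4-fluoro-1H-indol-3-yl in place of 5-fluoro-1H-indol-3-yl on a double-bonded ring carbon gives an at least 3.3-fold lower number from compound 3 to compound 4 (0.52 log units; beyond the scatter). Going by these compounds alone, this is the first pair here that differs in one place, and it shows that the site of the fluorine on the indole alone, with the same atoms and the amide link kept, is enough to change the result beyond the scatter and to bring a measured number, as compound 4 gives 1490 nM. Compound 3 has only a limit, so this step is a lower bound on the change and its full size cannot be read: the limit of > 5000 nM in this assay, at which 1 of the 4 values shown sits.

The compounds shown leave open whether the fluorine itself matters at this place, since they include no comparison with an unsubstituted 1H-indol-3-yl or with a chlorine or a methoxy group on the same indole carbon. They also leave open whether moving the fluorine would give a step of similar size if the amide carbonyl were replaced by a plain methylene link to the ring nitrogen.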